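A Chloro Group Added to the Thiazole Aryl Ring

The compounds below may be only part of what the source reports. "The series", "measured", "known", "first", "only" and "open" are said of these compounds alone.

Measured so far:
- compound 1 `Cc1nc(-c2ccc(Cl)cc2)sc1C(=O)CSc1nc(-c2ccccc2)c(C#N)c(=O)[nH]1`: in a functional assay on U-87MG ATCC cells for antiproliferative activity against U-87 MG (Homo sapiens), read by MTT assay, with a stated time of 48 h, tested at 10 uM (on this read-out higher numbers stand for a weaker effect at the one concentration tested and lower numbers for a stronger effect), compound 1 gives 83.1%
- compound 2 `COc1cccc(-c2nc(SCC(=O)c3sc(-c4ccccc4)nc3C)[nH]c(=O)c2C#N)c1`: in this assay compound 2 gives 90.2%

Compound 2 stands at the higher of these two numbers, but compound 1 lies within the usual scatter of it, so the two compounds cannot be told apart on this read-out. Compound 3 `COc1cccc(-c2nc(SCC(=O)c3sc(-c4ccc(Cl)cc4)nc3C)[nH]c(=O)c2C#N)c1` has not yet been measured. It differs from compound 2 in one place: chloro in place of hydrogen on an aromatic carbon. Cut one bond further out, the same change reads phenyl to 4-chlorophenyl. For the measured compounds named here, no pair of measured compounds differs in this one place alone, so no measured step shows what the change does on its own; compounds 1 and 2 differ in two places at once, and their values sit within the scatter of each other. On that basis the step of a number 4.2 percentage points lower from compound 2 to compound 3 (within the scatter) is expected to be small, with no clear direction beyond the scatter. Compound 3 is therefore estimated at 86%, with a likely range from 72% to 98%.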

Compound 3, a percentage reported as activity, at one concentration (the size of the read-out at that concentration, not a potency): 89.7%
The estimate for compound 3 lay 3.7 percentage points below the measured number, and the stated range covers the measured number.
By their numbers in this assay, from the lowest: compounds 1, 3 and 2 (each within the scatter of the next).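

In this assay, for the compounds shown here, the step of a number 0.5 percentage points lower from compound 2 to compound 3 (within the scatter) is the first measured comparison of chloro with hydrogen alone, on an aromatic carbon para to a large group, and phenyl and 4-chlorophenyl cannot be told apart at this position. The step of a number 6.6 percentage points higher from compound 1 to compound 3 (within the scatter) isolates the methoxy group that compound 3 carries and compound 1 lacks, on a different part of the molecule, and these two compounds likewise cannot be told apart, so neither single change shifts the read-out beyond the usual scatter in these compounds. Nothing available here offers an explanation for either result.

On these data alone, these comparisons cover only chloro at this position and a single methoxy change elsewhere, so it remains open whether a quite different group on the same aromatic carbon, such as an amine, a carboxylic acid or a longer alkoxy chain, would give a number beyond the scatter. As far as these compounds go, it also remains open whether chloro would look the same on a different core, or at a concentration other than the single one tested.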